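This account rests on a few compounds, and the source may have more. Where it says the series, first, only, none or still open, it means among the compounds named here.

Values in a functional assay (aorta) with Rattus norvegicus as the target; on this read-out lower numbers stand for stronger inhibition and higher numbers for weaker inhibition:
- Compound 1 `CCN(CC)CCCOc1ccc(S(=O)(=O)c2c(C)cn3ccccc23)cc1`: 3390 nM
- Compound 2 `CC(C)c1cn2ccccc2c1S(=O)(=O)c1ccc(OCCCN2CCC(c3ccccc3)CC2)cc1`: 80.9 nM
- Compound 3 `CCCCCCCCN(CCCCCCCC)CCCOc1ccc(S(=O)(=O)c2c(C(C)C)cn3ccccc23)cc1`: 30100 nM

Compound 2 has the lowest of the three numbers, and compound 1 and compound 3 both lie above it, beyond the scatter. Compound 4 `COc1ccc(CNCCCOc2ccc(S(=O)(=O)c3c(C(C)C)cn4ccccc34)cc2)cc1OC` departs from compound 2 in one place: (3,4-dimethoxybenzyl)amino in place of 4-phenylpiperidin-1-yl on a saturated chain carbon, three bonds along the chain from an oxygen on an aromatic ring. It carries (3,4-dimethoxybenzyl)amino in place of 4-phenylpiperidin-1-yl. Among the compounds with values here, no measured pair shows this change alone, so the expectation rests only on the spread from compound 2 at 80.9 nM to compound 3 at 30100 nM. A moderate move to a higher number, meaning weaker inhibition in this assay, is expected, with an estimated size of a 3.7-fold higher number from compound 2 to compound 4 (0.57 log units; beyond the scatter). For compound 4 the estimated value is 300 nM, with an expected range of 70 nM to 1500 nM.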

Compound 4, half-maximal inhibitory concentration: 13 nM
The estimate for compound 4 lay 23-fold (1.36 log units) above the measured number, and the stated range ends above it.
By their numbers in this assay, from the lowest: compound 4; then compound 2; then compound 1; then compound 3.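

In this assay, the place on a saturated chain carbon, three bonds along the chain from an oxygen on an aromatic ring, accepts an amine that is not part of a ring: (3,4-dimethoxybenzyl)amino in place of 4-phenylpiperidin-1-yl gives a 6.2-fold lower number from compound 2 to compound 4 (0.79 log units; beyond the scatter). The change removes the six-membered non-aromatic ring and adds a hydrogen-bond donor, yet the number falls rather than rises. Nothing available here explains this step. As far as these compounds go, whether a plain benzylamino group, without the two methoxy groups, would give a similar number remains open, so the contribution of those methoxy groups cannot be separated from that of the amine.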